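The compounds below may be only part of what the source reports. "The series", "measured", "known", "first", "only" and "open" are said of these compounds alone.

Two compounds in this series are in hand. Compound 1 `Cc1c(OCCCCOc2ccc(C(=O)O)cc2Cl)ccc(C(=O)CC2CCCC2)c1O` in an assay on HEK293 cells for positive allosteric modulation of metabotropic glutamate receptor 2 (Rattus norvegicus), read by thallium flux, with a stated time of 2.5 min (a higher number here means a larger maximal response, a lower number a smaller maximal response), gives 82.2%. Compound 2 `COC(=O)c1ccc(OCCCCOc2ccc(C(=O)CC(C)C)c(O)c2C)cc1` in this assay gives 16.4%, the lower of the two numbers, and the gap to compound 1 lies beyond the scatter. Compound 3 `Cc1c(OCCCCOc2ccc(C(=O)O)cc2Cl)ccc(C(=O)CC(C)C)c1O` is not yet measured. It differs from compound 2 in one place: 4-carboxy-2-chlorophenyl in place of 4-(methoxycarbonyl)phenyl on an oxygen on a saturated carbon. Going by the values given here, compound 1 also carries the 4-carboxy-2-chlorophenyl, while differing from compound 3 elsewhere in the structure, so no clean single step between measured compounds is available. Even so, a clear upward move is expected for compound 3 because compound 1 gives 82.2% with that group in place. The step that this estimate implies, a number 48.6 percentage points higher from compound 2 to compound 3 (beyond the scatter), is expected to be large and upward. For compound 3 the estimate in this assay is 65%, with a range from 35% to 90%.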

Compound 3, largest response reached (reported as percent of maximum), in percent of the reference or control that the assay uses: 99.5%
Beside the measured number, compound 3's estimate is 34.5 percentage points below it; the whole stated range lies below it.
By their numbers in this assay, from the lowest: compound 2; then compound 1; then compound 3.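

In this assay, 4-carboxy-2-chlorophenyl in place of 4-(methoxycarbonyl)phenyl gives a number 83.1 percentage points higher from compound 2 to compound 3 (beyond the scatter) with the rest of the structure held constant, so this position alone carries a large change in maximal response, which the earlier pair, differing in two places, could not show. The other place now has its own reading: isopropyl in place of cyclopentyl on the saturated chain carbon bound to a carbonyl carbon gives a number 17.3 percentage points higher from compound 1 to compound 3 (beyond the scatter) and is modest beside the first step. No evidence bearing on the cause of either step is at hand.

The large step combines the carboxylic acid in place of the methyl ester with the added chlorine, and the compounds shown do not separate the two; a plain 4-carboxyphenyl group would. As far as these compounds go, whether a tert-butyl group on that chain carbon keeps the response also remains open.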